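The source may hold more compounds than are shown below. What is called first, only, known or untested is meant among the compounds shown, and "the series" means these compounds.

In a functional assay with Oryctolagus cuniculus as the target (on this read-out lower numbers stand for stronger inhibition and higher numbers for weaker inhibition), compound 1 `COc1ccc(-c2nc(N=C(N)N)sc2-c2ccc(OC)cc2)cc1` gives 31000 nM. For compound 2 `CC/N=C(/N)Nc1nc(-c2ccc(OC)cc2)c(-c2ccc(OC)cc2)s1`, the entry > 100 nM is a limit and not a number. For compound 3 `COc1ccc(-c2nc(/N=C(\N)NC(C)C)sc2-c2ccc(OC)cc2)cc1`, the entry > 100 nM is likewise a limit and not a number. Compound 3 therefore stands on (the limit of > 100 nM in this assay, at which 2 of the 3 values shown sit), with no readable potency of its own.

Compound 4 `COc1ccc(-c2nc(/N=C(\N)N(C)C)sc2-c2ccc(OC)cc2)cc1` has dimethylamino in place of isopropylamino on a carbon with a double bond to nitrogen.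

Among the compounds with values here, three measured steps bear on this change, and none has a readable size: a step that the limit leaves unreadable from compound 1 to compound 3, a step that the limit leaves unreadable from compound 1 to compound 2 and a step that the two limits leave unreadable from compound 2 to compound 3. They give neither a size nor a direction for substitution on this nitrogen. Within the data shown here, the only real number is that of compound 1, at 31000 nM, so the expectation is anchored there, with a wide margin.

No step beyond the scatter is expected, and the estimated change is a step that the limit leaves unreadable from compound 3 to compound 4. The estimate for compound 4 is 30000 nM, with an expected range from 3000 nM to 200000 nM.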

Compound 4, half-maximal inhibitory concentration: 37 nM
Compound 4: middle estimate off by 810-fold (2.91 log units), on the high side; measured number outside the range, below it.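

In this assay, the series now has a readable size for substitution on this nitrogen, an 840-fold lower number from compound 1 to compound 4 (2.92 log units; beyond the scatter), and that size is large. Dimethylamino in place of isopropylamino gives an at least 2.7-fold lower number from compound 3 to compound 4 (0.43 log units; beyond the scatter), and the change of group on the aromatic carbon gives an at least 2.7-fold lower number from compound 2 to compound 4 (0.43 log units; beyond the scatter); each of these two steps starts from a limit and is therefore bounded on one side only: the limit of > 100 nM in this assay, at which 2 of the 4 values shown sit. The direction is now set for this pair, with the entering dimethylamino carrying no hydrogen-bond donor where the leaving isopropylamino carries one, though nothing here ties the step to that count.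

As far as these compounds go, the true size of the step from isopropylamino to dimethylamino stays open, as compound 2 and compound 3 have only limits. From the compounds shown here alone, whether methylamino or diethylamino on the same carbon would behave like dimethylamino also remains unknown.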